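Fluoro for hydroxy on the shared core: an expected rebound

The source may hold more compounds than are shown below. What is called first, only, known or untested is meant among the compounds shown, and "the series" means these compounds.

Measured so far:
compound 1 `Clc1ccc(Nc2ccc(N3CC4CC(C3)N4)cn2)cc1` — 2.49 nM
compound 2 `O=[N+]([O-])c1ccc(Nc2ccc(N3CC4CC(C3)N4)cn2)cc1` — 1.76 nM
compound 3 `Oc1ccc(Nc2ccc(N3CC4CC(C3)N4)cn2)cc1` — 7.1 nM

In an assay on cell membranes for displacement of a labelled ligand from Neuronal acetylcholine receptor; alpha4/beta2 (Rattus norvegicus) (a lower number here means a stronger inhibitor, a higher number a weaker inhibitor), compound 3 gives the highest of the three numbers. The step to it from the chloro analogue, a 2.9-fold higher number from compound 1 to compound 3 (0.46 log units; beyond the scatter), and from the nitro analogue, a 4.0-fold higher number from compound 2 to compound 3 (0.61 log units; beyond the scatter), both lie beyond the scatter, whereas a 1.4-fold lower number from compound 1 to compound 2 (0.15 log units; within the scatter) does not. Compound 4 `Fc1ccc(Nc2ccc(N3CC4CC(C3)N4)cn2)cc1` differs from compound 3 by fluoro in place of hydroxy on an aromatic carbon, a change that undoes the hydroxy of compound 3 in favour of a second halogen. The step from compound 1 to compound 3 bears most directly on it, read in reverse. The author therefore expects compound 4 to return toward the level of compound 1, a modest lowering of the number, a 2.4-fold lower number from compound 3 to compound 4 (0.37 log units; beyond the scatter), with an estimate of 3 nM in this assay, between 1.5 nM and 7 nM.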

Compound 4, inhibition constant: 2.38 nM
Compound 4: middle estimate off by 1.3-fold (0.10 log units), on the high side; the range from low to high includes it.
By their numbers in this assay, from the lowest: compounds 2, 4 and 1 (each within the scatter of the next); then compound 3.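

At this position, the hydroxy of compound 3 is what sets it apart from the other compounds: fluoro in its place gives a 3.0-fold lower number from compound 3 to compound 4 (0.47 log units; beyond the scatter), a step that removes one hydrogen-bond donor and one acceptor. Fluoro then falls level with both earlier analogues, with a 1.0-fold lower number from compound 1 to compound 4 (0.02 log units; within the scatter) and a 1.4-fold higher number from compound 2 to compound 4 (0.13 log units; within the scatter), so fluoro, chloro and nitro cannot be told apart here.

No evidence is available to explain why the hydroxy compound stands apart. As far as these compounds go, whether an amine or a methoxy group here would sit with compound 3 or with the other three remains open.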